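The source may report more compounds than this note shows. Statements on the series, on what has been measured and on what is new or still open speak of the compounds shown alone.

Compound 1 `Cc1ncnc2c1c(I)cn2[C@@H]1O[C@H](CO)[C@@H](O)[C@H]1O`: in an ADME assay on BJ cells (Homo sapiens), read by MTT assay, with a stated time of 72 h (a higher number here means a weaker inhibitor, a lower number a stronger inhibitor), compound 1 reaches only the limit > 100000 nM, which is a limit of the assay and not a number.
Compound 2 `CNc1ncnc2c1c(I)cn2[C@@H]1O[C@H](CO)[C@@H](O)[C@H]1O`: in this assay compound 2 likewise reaches only the limit > 100000 nM, again a limit rather than a number.

Within the data shown here, compound 2 therefore stands at the limit of this assay, and the one step measured so far, a step that the two limits leave unreadable from compound 1 to compound 2, cannot be read in size, because both of its ends sit at the same limit (the limit of > 100000 nM in this assay, at which 2 of the 2 values shown sit). Compound 3 `CNc1ncnc2c1c(-c1ccco1)cn2[C@@H]1O[C@H](CO)[C@@H](O)[C@H]1O` differs from compound 2 by a single change, (furan-2-yl in place of iodo on an aromatic carbon). Among the measured compounds shown here, no measured step involves this exchange, and the step from compound 1 to compound 2 gives no readable size, so nothing in the numbers points to a direction or a size for compound 3 in this assay beyond the scatter. Compound 3 is estimated to sit near the limit, at 60000 nM, within 10000 nM to 200000 nM, which means an expected step of an at least 1.6-fold lower number from compound 2 to compound 3 (0.22 log units; that floor lies within the scatter).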

Compound 3, half-maximal inhibitory concentration: 5040 nM
The estimate for compound 3 lay 12-fold (1.08 log units) above the measured number, and the stated range ends above it.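

This aromatic carbon of the five-membered ring, two ring bonds from the ring nitrogen, turns out to be a place where a change can be read. With the methylamino group kept, furan-2-yl in place of iodo in this assay gives an at least 19-fold lower number from compound 2 to compound 3 (1.29 log units; beyond the scatter). That size is only a floor, and compound 3 is the one compound shown that carries a real number rather than a limit: the limit of > 100000 nM in this assay, at which 2 of the 3 values shown sit.

The compounds shown do not tell whether this gain belongs to the furan-2-yl group itself or would also come with another ring, such as thiophene or phenyl, or with a simple amine or a carboxylic acid at the same carbon. From the compounds shown here alone, the step from methyl to methylamino cannot be read, so it also stays open whether that exchange would matter once furan-2-yl is present.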